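Ring Size at the Thiocarbonyl Carbon in Chromone Dithiocarbamates

The source may report more compounds than this note shows. Statements on the series, on what has been measured and on what is new or still open speak of the compounds shown alone.

Measured compounds:
- compound 1 `O=c1c(SC(=S)N2CCCCC2)coc2ccccc12`: 17400 nM
- compound 2 `O=c1c(SC(=S)N2CCCC2)coc2ccccc12`: 1900 nM
- compound 3 `CCOC(=O)c1cc(=O)c2cc(CSC(=S)N3CCCC3)ccc2o1`: 3400 nM

All three were tested in a functional assay on MDA-MB-435S cells (Homo sapiens) for antiproliferative activity, read by MTT assay, with a stated time of 72 h; a higher number here means a weaker inhibitor, a lower number a stronger inhibitor. Compound 2 gives 1900 nM, and compound 1, which carries piperidin-1-yl in place of pyrrolidin-1-yl on a thiocarbonyl carbon, gives 17400 nM. That single change produced a 9.2-fold higher number from compound 2 to compound 1 (0.96 log units; beyond the scatter), so the larger ring on the thiocarbonyl carbon went with a clearly weaker compound in this pair.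

Compound 3 gives 3400 nM in this assay. Its core is not the same as that of compound 2, and the difference between the two cores is not broken down here; their values lie close to each other, within the usual scatter, so no order between them can be stated. Against compound 1, compound 3 stands clearly lower.

Compound 4 `CCOC(=O)c1cc(=O)c2cc(CSC(=S)N3CCCCC3)ccc2o1` has not yet been measured. It differs from compound 3 by piperidin-1-yl in place of pyrrolidin-1-yl on a thiocarbonyl carbon, at a place that is described in the same words as for the step from compound 2 to compound 1, so this is the same change made on a different core. For the measured compounds named here, on that ground compound 4 is expected to show a 5.9-fold higher number from compound 3 to compound 4 (0.77 log units; beyond the scatter), a step of a size like the one seen between compound 2 and compound 1, though the different core leaves room for a smaller or larger shift. The estimate for compound 4 in this assay is 20000 nM, with a likely range from 6000 nM to 70000 nM.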

Compound 4, half-maximal inhibitory concentration: 2900 nM
The estimate for compound 4 lay 6.9-fold (0.84 log units) above the measured number; the measured number lies below the stated range.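

In this assay, putting piperidin-1-yl in place of pyrrolidin-1-yl on the thiocarbonyl carbon of the core of compound 3 gives a 1.2-fold lower number from compound 3 to compound 4 (0.07 log units; within the scatter), so on this core the two rings cannot be told apart. The result of this change therefore did not carry over from the core of compound 2, where the larger ring went with a clearly weaker compound, and the gap between the two steps is real rather than a matter of ordinary assay noise: the same change on two cores in this assay, a 9.2-fold higher number (0.96 log units; beyond the scatter) from compound 2 to compound 1 and a 1.2-fold lower number (0.07 log units; within the scatter) from compound 3 to compound 4, 11-fold (1.03 log units) apart, beyond the scatter of two such steps This shows that, in this series, the step seen on one core cannot simply be transferred to another, but it does not show which feature of the cores is responsible, as the difference between them is not broken down by these two pairs of compounds.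

Still open, going by these compounds, is how other groups on the thiocarbonyl carbon, such as morpholin-4-yl or diethylamino, would behave on each of the two cores. On these data alone, it is also open whether a carboxylic acid in place of the ethyl ester in compound 3 and compound 4 would leave the two rings indistinguishable or bring back a gap like the one on the other core.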